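The source may report more compounds than this note shows. Statements on the series, on what has been measured and on what is new or still open speak of the compounds shown alone.

Compound 1 `OCCCNc1nc(-c2ccccc2)nc2c1nnn2Cc1ccccc1Cl` gives 33000000 nM in an assay on isolated protein for binding affinity to adenosine receptor A1 (Bos taurus) (on this read-out higher numbers stand for weaker inhibition and lower numbers for stronger inhibition), and stands highest of the three numbers here. Compound 3 `OCCCNc1nc(-c2ccccc2)nc2c1nnn2Cc1ccccc1` gives 21400000 nM in this assay, and the step of a 1.5-fold lower number from compound 1 to compound 3 (0.19 log units; within the scatter) is within the scatter. For the measured compounds named here, compound 2 `Fc1ccccc1Cn1nnc2c(NC3CC3)nc(-c3ccccc3)nc21` gives 15000000 nM in this assay, a number separated from compound 1 by a gap beyond the scatter, but no single-point step links the two. Compound 4 `CCCCCCNc1nc(-c2ccccc2)nc2c1nnn2Cc1ccccc1Cl` differs from compound 1 by propyl in place of hydroxy on a saturated chain carbon, three bonds along the chain from a nitrogen on an aromatic ring. Going by the values given here, none of the measured steps touches this place on the chain, so no precedent for its size or direction exists. On that basis compound 4 is expected to show a 1.1-fold lower number from compound 1 to compound 4 (0.04 log units; within the scatter), a step not beyond the scatter. Compound 4 is therefore estimated at 30000000 nM in this assay, with a range from 6000000 nM to 150000000 nM.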

Compound 4, inhibition constant: 31000000 nM
Estimate against measurement, compound 4: 1.0-fold (0.01 log units) below; the measured number falls inside the stated range.
By their numbers in this assay, from the lowest: compounds 2, 3, 4 and 1 (each within the scatter of the next, the first and the last beyond it).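

For the compounds shown here, this is the first reading at this place on the chain. In this assay, the change from 3-hydroxypropyl to hexyl gives a 1.1-fold lower number from compound 1 to compound 4 (0.03 log units; within the scatter), so exchanging hydroxy, a hydrogen-bond donor and acceptor, for propyl, which is neither, does not separate the two compounds. No independent measurement bears on this result.

From the compounds shown here alone, whether an amine or a carboxylic acid at this place on the chain would stay within the scatter of compound 1 remains open. So does the effect of a chain longer than hexyl.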